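A Second Methoxy Placement on the Benzoyl Ring

The source may report more compounds than this note shows. Statements on the series, on what has been measured and on what is new or still open speak of the compounds shown alone.

Compound 1 `COc1ccc2c(c1)c(-c1nc3ccccc3n1C(=O)c1ccccc1)cn2C` gives 16700 nM in a functional assay on A549 cells (Homo sapiens) for inhibition, read by MTT assay, with a stated time of 24 h; a higher number here means a weaker inhibitor of growth, a lower number a stronger inhibitor of growth. Compound 2 `COc1cccc(C(=O)n2c(-c3cn(C)c4ccc(OC)cc34)nc3ccccc32)c1` differs from it by methoxy in place of hydrogen on an aromatic carbon and gives 4600 nM in this assay, so that a 3.6-fold lower number from compound 1 to compound 2 (0.56 log units; beyond the scatter). Compound 3 `Cn1cc(-c2nc3ccccc3n2C(=O)c2ccccc2)c2cc(Br)ccc21` differs from compound 1 in its core by bromo in place of methoxy on an aromatic carbon; in this assay compound 3 gives 23100 nM, and a 1.4-fold higher number from compound 1 to compound 3 (0.14 log units; within the scatter).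

Compound 4 `COc1ccccc1C(=O)n1c(-c2cn(C)c3ccc(Br)cc23)nc2ccccc21` has not yet been measured. It differs from compound 3 by methoxy in place of hydrogen on an aromatic carbon. This is the same kind of change as that from compound 1 to compound 2, but not the same: there the methoxy stood meta to a large group, here it stands ortho to a large group, and the core carries bromo rather than methoxy. Because of a 3.6-fold lower number from compound 1 to compound 2 (0.56 log units; beyond the scatter) a lower number is expected for compound 4, but with the placement shifted the step is estimated smaller, a 1.9-fold lower number from compound 3 to compound 4 (0.28 log units; within the scatter). Compound 4 is therefore expected to give about 12000 nM in this assay, within the range 5000 nM to 30000 nM.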

Compound 4, concentration for 50% growth inhibition: 12800 nM
The estimate for compound 4 lay 1.1-fold (0.03 log units) below the measured number, within the range that was stated.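

Compound 4 carries 2-methoxyphenyl where compound 3 carries phenyl, and in this assay this gives a 1.8-fold lower number from compound 3 to compound 4 (0.26 log units; within the scatter) so that this step, taken alone, cannot be told apart from repeat scatter. The two methoxy steps point the same way, but they are only two, and the methoxy stands at a different place on the benzoyl ring in each while the cores also differ, so the pair cannot separate the effect of the core from that of the placement, nor show that the change has a real effect on the core of compound 3. What can be said is that the size of the change does not measurably depend on which of these two pairs carries it: the same change on two cores in this assay, a 3.6-fold lower number (0.56 log units; beyond the scatter) from compound 1 to compound 2 and a 1.8-fold lower number (0.26 log units; within the scatter) from compound 3 to compound 4, 2.0-fold (0.30 log units) apart, within the scatter of two such steps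

The compounds shown leave open how each methoxy placement would behave if it were held fixed and only the core changed, with the 2-methoxyphenyl group on the core of compound 1 as one such case. They also leave open whether an amine, a carboxylic acid or a longer chain on the benzoyl ring would move the number in the same direction on both cores.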